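From Hydroxy to Isopropoxy on Compound 3

The source may report more compounds than this note shows. Statements on the series, on what has been measured and on what is new or still open speak of the compounds shown alone.

Of the compounds shown here, three have numbers so far: compound 1 (`CC1=C2CC(C)(C)/C=C/C(=O)/C(C)=C\C3=C[C@H](C)C[C@]3(O2)[C@@]1(O)C(F)(F)F`), compound 2 (`C/C1=C/C2=C[C@H](C)C[C@@]23O[C@]2(CC(C)(C)[C@@H](Br)[C@@H]2C1=O)[C@](C)(Br)C3=O`) and compound 3 (`C/C1=C/C2=C[C@H](C)C[C@@]23O[C@]2(CC(C)(C)[C@@H](O)[C@@H]2C1=O)[C@@H](C)C3=O`). In an ADME assay on Raji cells (Homo sapiens) for cytotoxicity, read by CellTiter-Glo, with a stated time of 72 h (a lower number here means that less compound is needed, a higher number that more compound is needed for the effect), compound 3 gives 26000 nM as its reading, and compound 1 gives 26000 nM as well, so the two stand level at the top of the three numbers. Compound 2 gives 4380 nM as its reading, lower than compound 3 by more than the usual scatter of repeated measurements.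

The next compound is compound 4 (`C/C1=C/C2=C[C@H](C)C[C@@]23O[C@]2(CC(C)(C)[C@@H](OC(C)C)[C@@H]2C1=O)[C@@H](C)C3=O`). The structural change from compound 3 is isopropyl in place of hydrogen on an oxygen on a saturated carbon in one place: isopropyl in place of hydrogen on an oxygen on a saturated carbon, which reads as hydroxy to isopropoxy. Going by the values given here, no two measured compounds differ in a single place, so nothing yet shows what such a change does here. Compound 2 differs from compound 3 in more than one place and offers no direct guide. The expectation therefore takes compound 3 at 26000 nM as its starting point. In this assay no step beyond the scatter is expected in either direction, and the estimated 1.3-fold lower number from compound 3 to compound 4 (0.11 log units; within the scatter) stays small. For compound 4 the estimate is 20000 nM in the middle, with an expected range from 7000 nM to 50000 nM for a measurement.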

Compound 4, half-maximal effective concentration: 26000 nM
The estimate for compound 4 lay 1.3-fold (0.11 log units) below the measured number; the measured number falls inside the stated range.
By their numbers in this assay, from the lowest: compound 2; then compounds 1, 3 and 4 (each within the scatter of the next).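

In this assay, going by these compounds alone, putting isopropyl in place of hydrogen on the oxygen gives no change at the digits printed from compound 3 to compound 4 (within the scatter), and this is the first step in the set that changes just one place, so the effect of a change at this position can now be read directly. For this pair, hydroxy and isopropoxy on this saturated carbon give the same reading, which shows that the hydrogen on that oxygen can be exchanged for this branched group with no visible shift in the number. Nothing available here explains why the reading stays the same, so the result describes what happened and gives no reason for it.

This single step says nothing yet about other groups at this position, such as an amine in place of the oxygen, a carboxylic acid, or a longer chain on the oxygen, any of which might either leave the number where it is or move it. From the compounds shown here alone, it also remains open whether hydroxy to isopropoxy would give the same result on a different core or at another position on this one.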